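Bicyclic Amine in Place of the Ethylpiperazine

A few compounds are considered here, and "the series" means these few. Any claim that something is new, unique, unknown or untested is made for them only; others in the source may bear on it.

Three compounds have been measured in an ADME assay on microsomes from liver (Homo sapiens) for metabolic stability, read by LC-MS, with a stated time of 10 min; on this read-out higher numbers stand for a more stable compound and lower numbers for a less stable compound:
Compound 1 `C[C@@H]1CN(c2cccc3c2C[C@H](CN(C)[C@H]2CCCc4cccnc42)NC3)C[C@H](C)N1` gives 100%.
Compound 2 `CN(C[C@H]1Cc2c(cccc2N2CCNCC2)CN1)[C@H]1CCCc2cccnc21` gives 99.7%.
Compound 3 `CCN1CCN(c2cccc3c2C[C@H](CN(C)[C@H]2CCCc4cccnc42)NC3)CC1` gives 0%.

Compound 3 stands lowest of the three in this assay; its nearest neighbour is compound 2, and the gaps to both other compounds lie beyond the scatter. Two measured steps end at compound 3. From compound 1 the change was a number 100 percentage points lower from compound 1 to compound 3 (beyond the scatter). From compound 2 it was a number 99.7 percentage points lower from compound 2 to compound 3 (beyond the scatter). The step of a number 0.3 percentage points lower from compound 1 to compound 2 (within the scatter), by contrast, shows the two compounds whose ring amine nitrogen carries a hydrogen sitting together at the top.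

Compound 4 `CN(C[C@H]1Cc2c(cccc2N2CCN3CCC[C@@H]3C2)CN1)[C@H]1CCCc2cccnc21` has not been measured yet. It differs from compound 3 in this way: a group of 9 heavy atoms (7 carbon, 2 nitrogen; one five-membered non-aromatic ring with 1 hetero atom, one six-membered non-aromatic ring with 2 hetero atoms) in place of a group of 8 heavy atoms (6 carbon, 2 nitrogen; one six-membered non-aromatic ring with 2 hetero atoms), on an aromatic carbon. As in compound 3, the amine nitrogen in the ring of compound 4 carries no hydrogen. For the measured compounds named here, the two steps leading to compound 3 were both very large drops, and nothing measured so far separates a tertiary ring amine of one shape from another, so compound 4 is expected to remain close to compound 3 rather than recover the level of compound 1 or compound 2. The step of a number 12 percentage points higher from compound 3 to compound 4 (beyond the scatter) is expected to be small and upward, possibly within the scatter. Compound 4 is estimated at 12%, with a range from 0% to 45%.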

Compound 4, percent of the compound remaining: 52.2%
For compound 4 the middle estimate is 40.2 percentage points below the measured one; the whole stated range lies below it.
By their numbers in this assay, from the lowest: compound 3; then compound 4; then compounds 2 and 1 (each within the scatter of the next).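

On this aromatic carbon, replacing the 4-ethylpiperazin-1-yl group with a two-ring group, which has a five-membered ring as well as the six-membered one, gives a number 52.2 percentage points higher from compound 3 to compound 4 (beyond the scatter) in this assay and shows that a ring amine nitrogen without a hydrogen does not by itself hold a compound at the bottom of this read-out. The recovery is only partial, as the two-ring group also gives a number 47.5 percentage points lower from compound 2 to compound 4 (beyond the scatter) and a number 47.8 percentage points lower from compound 1 to compound 4 (beyond the scatter). Compound 1 and compound 2, whose ring amine nitrogen carries a hydrogen, still stand at the top. This position therefore gives three distinct levels rather than two, with the shape of the group on the ring amine nitrogen making a difference among the compounds that lack that hydrogen.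

The information available offers no measurement that explains why the two-ring group stands apart from the 4-ethylpiperazin-1-yl group. Still open, from the compounds shown here alone, is whether a 4-methylpiperazin-1-yl group would fall nearer compound 3 or compound 4, and whether the two-ring group with its stereocentre inverted would give a similar number.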